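From 2-ethylphenyl to 3-cyanophenyl on a shared core

The source may hold more compounds than are shown below. What is called first, only, known or untested is meant among the compounds shown, and "the series" means these compounds.

Among the measured compounds shown here, in a functional assay (muscle tissue) with Cavia porcellus as the target (a higher number here means that more compound is needed for the effect, a lower number that less compound is needed), compound 3 `CCc1ccccc1C1C(C(=O)OC)=C(C)N=C(C)/C1=C(\O)OC` gives 6.46 nM, the lowest of the three numbers so far. Compound 1 `COC(=O)C1=C(C)N=C(C)/C(=C(\O)OC)C1c1cccc(OC)c1` gives 191 nM, and compound 2 `COC(=O)C1=C(C)N=C(C)/C(=C(\O)OC)C1c1ccc(Cl)cc1` gives 8130 nM.

Compound 4 `COC(=O)C1=C(C)N=C(C)/C(=C(\O)OC)C1c1cccc(C#N)c1` has 3-cyanophenyl in place of 2-ethylphenyl on a saturated ring carbon. All three measured steps exchange the group at this same place, and all are large: a 43-fold higher number from compound 1 to compound 2 (1.63 log units; beyond the scatter), a 30-fold lower number from compound 1 to compound 3 (1.47 log units; beyond the scatter) and a 1300-fold lower number from compound 2 to compound 3 (3.10 log units; beyond the scatter). The group on compound 1, 3-methoxyphenyl, is the nearest by name to the incoming one, and the step of a 30-fold lower number from compound 1 to compound 3 (1.47 log units; beyond the scatter) suggests that leaving 2-ethylphenyl for such a group could cost much. For the measured compounds named here, no compound with a nitrile has been measured, so this guide is rough. A clear step towards a higher number is therefore expected in this assay, probably smaller than the gap to compound 1. The expected step is a 7.7-fold higher number from compound 3 to compound 4 (0.89 log units; beyond the scatter). For compound 4 the estimated value is 50 nM, with an expected range from 8 nM to 300 nM.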

Compound 4, half-maximal effective concentration: 34.7 nM
Beside the measured number, compound 4's estimate is 1.4-fold (0.16 log units) above it, and the stated range covers the measured number.
By their numbers in this assay, from the lowest: compound 3; then compound 4; then compound 1; then compound 2.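

In this assay, the 3-cyanophenyl group places compound 4 in the middle of the series: a 5.4-fold higher number from compound 3 to compound 4 (0.73 log units; beyond the scatter) and a 230-fold lower number from compound 2 to compound 4 (2.37 log units; beyond the scatter). Among the compounds shown here, the step of a 5.5-fold lower number from compound 1 to compound 4 (0.74 log units; beyond the scatter) is the first here in which the substituent changes while its printed ring number stays the same, so the choice of group on the aromatic ring matters even without moving to another ring position. Nothing available here explains these differences.

The compounds shown leave open whether the low number of compound 3 goes with the ethyl group or with its ring position, a question that 3-ethylphenyl and 2-cyanophenyl groups could separate. They also leave open how the assay would respond to a carboxylic acid or an amine on this aromatic ring.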